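The source may hold more compounds than are shown below. What is called first, only, known or untested is meant among the compounds shown, and "the series" means these compounds.

Measured so far:
- Compound 1 `O=C1/C(=C/c2ccc(F)cc2)CCCc2ccccc21`: 20000 nM
- Compound 2 `O=C1/C(=C/c2ccc(Cl)cc2)CCCc2ccccc21`: 15100 nM

Only these two compounds have been measured in a functional assay on CCRF-CEM cells (Homo sapiens) for inhibition; on this read-out lower numbers stand for stronger inhibition and higher numbers for weaker inhibition. Compound 2 gives 15100 nM, and compound 1 gives 20000 nM. These two values lie within the usual scatter of each other, so neither can be ranked above the other.

The next compound is compound 3 `O=C1/C(=C/c2ccc(Br)cc2)CCCc2ccccc21`, which keeps the shared core of compound 2. The change is bromo in place of chloro on an aromatic carbon, para to a large group.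

Among the measured compounds shown here, one measured step bears on this change, as it is also a swap of one halogen for another at the same place. That step, a 1.3-fold lower number from compound 1 to compound 2 (0.12 log units; within the scatter), puts chloro in place of fluoro. It is a single step, so it offers only thin guidance, but it gives no reason to expect a change beyond the scatter in this assay.

The expected result is a 1.1-fold lower number from compound 2 to compound 3 (0.03 log units; within the scatter), which would be no real change. For compound 3 the estimated value is 14000 nM, with an expected range from 7000 nM to 28000 nM.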

Compound 3, half-maximal inhibitory concentration: 17100 nM
Compound 3: the middle estimate sits 1.2-fold (0.09 log units) below what was measured; low and high end bracket the measured number.
By their numbers in this assay, from the lowest: compounds 2, 3 and 1 (each within the scatter of the next).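

In this assay, bromo in place of chloro gives a 1.1-fold higher number from compound 2 to compound 3 (0.05 log units; within the scatter) and bromo in place of fluoro gives a 1.2-fold lower number from compound 1 to compound 3 (0.07 log units; within the scatter), so both new steps stay inside the usual scatter. Where the earlier compounds offered a single halogen swap, all three pairs among fluoro, chloro and bromo can now be read at this place on the aromatic ring, para to a large group, and no pair separates, so the three halogens cannot be ranked here and the choice among them makes no visible difference on this read-out. No measurement at hand speaks to why the three numbers stay so close together.

The compounds shown carry only a halogen at this place, so they say nothing about how a quite different group, such as an amine, a carboxylic acid or a longer chain, would behave there. As far as these compounds go, it also stays open whether any change at this place, or elsewhere on the shared core, can move the number beyond the scatter at all.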